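Changing the Aryl Group: Expected Tolerance of Compound 4

The source may report more compounds than this note shows. Statements on the series, on what has been measured and on what is new or still open speak of the compounds shown alone.

Three compounds have been measured in an ADME assay on HUVEC cells (Homo sapiens) for cytotoxicity, read by MTT assay, with a stated time of 24 h; a higher number here means that more compound is tolerated, a lower number that less compound is tolerated:
Compound 1, `Brc1cccc(/C=C/c2nnc(-c3ccc4c(c3)OCCO4)o2)c1`, gives 322000 nM.
Compound 2, `Clc1ccccc1/C=C/c1nnc(-c2ccc3c(c2)OCCO3)o1`, gives 368000 nM.
Compound 3, `Cc1ccccc1/C=C/c1nnc(-c2ccc3c(c2)OCCO3)o1`, gives 356000 nM.

Compound 3 holds the second highest of these three numbers. Its nearest neighbour is compound 2, with a 1.0-fold lower number from compound 2 to compound 3 (0.01 log units; within the scatter); its furthest is compound 1, with a 1.1-fold higher number from compound 1 to compound 3 (0.04 log units; within the scatter). Compound 4, `COc1cccc(/C=C/c2nnc(-c3ccc4c(c3)OCCO4)o2)c1`, differs from compound 3 in one place: 3-methoxyphenyl in place of 2-methylphenyl on a double-bonded chain carbon bound to a double-bonded chain carbon. The earlier swaps of this same aryl group, a 1.1-fold higher number from compound 1 to compound 2 (0.06 log units; within the scatter) and a 1.1-fold higher number from compound 1 to compound 3 (0.04 log units; within the scatter), all stayed within the scatter, so no step beyond the scatter is expected here either, with a 1.0-fold lower number from compound 3 to compound 4 (0.01 log units; within the scatter). Compound 4 is therefore estimated at 345000 nM, with a range from 200000 nM to 560000 nM.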

Compound 4, half-maximal cytotoxic concentration: 332000 nM
Compound 4: the middle estimate sits 1.0-fold (0.02 log units) above what was measured; the range from low to high includes it.
By their numbers in this assay, from the lowest: compounds 1, 4, 3 and 2 (each within the scatter of the next).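

Placing 3-methoxyphenyl on this chain carbon brings an oxygen and a hydrogen-bond acceptor into the aryl group, yet the number stays within the scatter of all three earlier compounds (a 1.1-fold lower number from compound 3 to compound 4 (0.03 log units; within the scatter); a 1.1-fold lower number from compound 2 to compound 4 (0.04 log units; within the scatter); a 1.0-fold higher number from compound 1 to compound 4 (0.01 log units; within the scatter)). So in this assay the flat picture now extends to an oxygen-bearing group. Nothing available explains this flatness. Still open, from the compounds shown here alone, is whether an aryl group carrying an amine or a carboxylic acid would move the number beyond the scatter.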